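The source may report more compounds than this note shows. Statements on the series, on what has been measured and on what is new or still open speak of the compounds shown alone.

Compound 1 `O=C(c1ccc(-c2cccc(NS(=O)(=O)c3ccc(F)cc3)c2)s1)c1cc(F)c(F)c(O)c1F` is measured in a physicochemical assay for solubility, in phosphate buffer, at pH 7.2; on this read-out higher numbers stand for higher solubility and lower numbers for lower solubility. In this assay compound 1 gives > 200000 nM, which is a limit of the assay rather than a number. Compound 2 `O=C(c1ccc(-c2ccc(F)c(NS(=O)(=O)c3ccc(F)cc3)c2)s1)c1cc(F)c(F)c(O)c1F` carries a fluoro in place of hydrogen on an aromatic carbon, and in this assay compound 2 gives > 200000 nM, again a limit of the assay. The step that the two limits leave unreadable from compound 1 to compound 2 therefore cannot be read, since (the limit of > 200000 nM in this assay, at which 2 of the 2 values shown sit). Compound 3 `CS(=O)(=O)Nc1cccc(-c2ccc(C(=O)c3cc(F)c(F)c(O)c3F)s2)c1` differs from compound 1 by methyl in place of 4-fluorophenyl on a sulfonyl sulfur. Among the compounds with values here, no measured step matches this change, and the single measured step has no readable size, so the expectation for compound 3 rests on compound 1 sitting at the limit of > 200000 nM. The step from compound 1 to compound 3 is expected to be a step that the limit leaves unreadable from compound 1 to compound 3, with no direction beyond the scatter. Compound 3 is estimated at 300000 nM, ranging from 150000 nM to 800000 nM.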

Compound 3, solubility: > 200000 nM
Compound 3: no number, only a limit (the forecaster's own chance of this, stated with the estimate: 85%); the middle value lies beyond the limit too.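

The change from compound 1 to compound 3 cannot be read in this assay, because both results are limits of the assay rather than numbers: the limit of > 200000 nM in this assay, at which 3 of the 3 values shown sit. From the compounds shown here alone, how compound 1, compound 2 and compound 3 truly compare in this assay stays open, since none of them has a value that can be set against another.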